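A Methoxy for a Chloro on the Benzyl Ring

The source may report more compounds than this note shows. Statements on the series, on what has been measured and on what is new or still open speak of the compounds shown alone.

Three compounds share one core and differ only in the ring at the far end of the (2-chlorobenzyl)oxy arm. Compound 1 `COc1cccc(OC)c1OCCNCCOc1ccccc1OCc1ccccc1Cl` carries a chloro there; in a functional assay on thoracic aorta for antagonist activity at Alpha-1D adrenergic receptor (Rattus norvegicus) (a lower number here means a less potent compound, a higher number a more potent compound, by a factor of ten per unit of this negative logarithm), compound 1 gives 8.59. Compound 2 `COc1cccc(OC)c1OCCNCCOc1ccccc1OCc1ccccc1C` has a methyl in place of that chloro and gives 8.64 in this assay, while compound 3 `COc1cccc(OC)c1OCCNCCOc1ccccc1OCc1cccc(C)c1`, whose arm ends in a 3-methylphenyl instead, gives 8.85. Compound 1 thus holds the lowest of the three numbers, yet its gap to compound 2 a number 0.05 log units higher from compound 1 to compound 2 (within the scatter) and to compound 3 a number 0.26 log units higher from compound 1 to compound 3 (within the scatter) both sit within the scatter, so no order among the three can be claimed.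

Compound 4 `COc1ccccc1COc1ccccc1OCCNCCOc1c(OC)cccc1OC` is compound 1 with methoxy in place of chloro on an aromatic carbon. The step bearing most directly on it is the exchange of the same chloro for a methyl, a number 0.05 log units higher from compound 1 to compound 2 (within the scatter), which stayed within the scatter. Moving the methyl to give a 3-methylphenyl, a number 0.21 log units higher from compound 2 to compound 3 (within the scatter), also stayed within the scatter. Nothing seen so far shows this position to matter much, so the step to compound 4 is expected to be small, a number 0.06 log units higher from compound 1 to compound 4 (within the scatter). Compound 4 is therefore estimated at 8.65, with a range from 8.2 to 9.1.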

Compound 4, negative logarithm of the antagonist equilibrium constant: 8.86
Compound 4: middle estimate off by 0.21 log units, on the low side, within the range that was stated.
By their numbers in this assay, from the lowest: compounds 1, 2, 3 and 4 (each within the scatter of the next).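

Replacing the chloro with methoxy adds a heavy atom and a hydrogen-bond acceptor, yet the result is a number 0.27 log units higher from compound 1 to compound 4 (within the scatter) in this assay, so this position accepts an oxygen-linked group as well as the chloro and methyl groups seen earlier. Comparison with the two methyl compounds points the same way, with a number 0.22 log units higher from compound 2 to compound 4 (within the scatter) for the exchange of methyl for methoxy on the same ring carbon and a number 0.01 log units higher from compound 3 to compound 4 (within the scatter) for the 2-methoxyphenyl in place of the 3-methylphenyl, so all four compounds remain indistinguishable in this measurement and the added acceptor brings no detectable difference. Nothing in the data offers an explanation for this tolerance.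

As far as these compounds go, the four compounds cover only chloro, methyl and methoxy on this ring, so it remains open whether an amine, a carboxylic acid or a longer chain such as butoxy in place of the chloro would also stay within the scatter or would finally show that this position matters. How these same exchanges would behave at any other receptor also remains open, since only this assay is shown here.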